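This account rests on a few compounds, and the source may have more. Where it says the series, first, only, none or still open, it means among the compounds named here.

Three compounds were measured in an ADME assay on liver for metabolic stability, with Liver microsome (Homo sapiens) as the target, read by LC-MS, using microsomes; on this read-out higher numbers stand for fast clearance and lower numbers for slow clearance. Compound 1 `O=C(NCc1cc(Cl)ccc1-n1cnnn1)[C@@H]1CC=NN1C(=O)[C@H](O)c1ccccc1F` gives 16 mL.min-1.g-1. Compound 2 `CC(C)(C)C[C@@H](O)C(=O)N1N=CC[C@H]1C(=O)NCc1cc(Cl)ccc1-n1cnnn1` gives 22 mL.min-1.g-1. Compound 3 `CC(C)(C)C[C@@H](O)C(=O)N1[C@H](C(=O)NCc2cc(Cl)ccc2-n2cnnn2)C[C@@H]2C[C@@H]21` gives 40 mL.min-1.g-1; this number lies beyond the scatter from that of compound 1, while compound 2 and compound 3 lie within the scatter of each other. The difference between the core of compound 3 and the core of compound 2 is not broken down here.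

Compound 2 and compound 1 differ in one place: 2-fluorophenyl in place of neopentyl on a saturated chain carbon bound to a carbonyl carbon and an oxygen on a saturated carbon. That change made a 1.4-fold lower number from compound 2 to compound 1 (0.14 log units; within the scatter).

Compound 4 `O=C(NCc1cc(Cl)ccc1-n1cnnn1)[C@@H]1C[C@@H]2C[C@@H]2N1C(=O)[C@H](O)c1ccccc1F` has not yet been measured. It stands to compound 3 as compound 1 stands to compound 2: 2-fluorophenyl in place of neopentyl on a saturated chain carbon bound to a carbonyl carbon and an oxygen on a saturated carbon. The change thus appears twice among these compounds, on two different cores, with the same surroundings at the place of change in both cases, so it is the same change.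

Because the earlier step of a 1.4-fold lower number from compound 2 to compound 1 (0.14 log units; within the scatter) stayed within the scatter, the same change is expected to make a step of similar small size, a 1.3-fold lower number from compound 3 to compound 4 (0.12 log units; within the scatter). This rests on a single precedent on another core, so the expectation is loose. Compound 4 is accordingly estimated at 30 mL.min-1.g-1 in this assay, with a likely range from 15 mL.min-1.g-1 to 60 mL.min-1.g-1.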

Compound 4, intrinsic clearance in microsomes: < 12 mL.min-1.g-1
Compound 4: no number, only a limit; the forecaster's own chance of this, stated with the estimate: 5%; middle value at least 2.5-fold (0.39 log units) from the limit.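

In this assay compound 4 gives < 12 mL.min-1.g-1, which is a limit of the assay and not a number, and it is the only compound of the series shown to sit there: the limit of < 12 mL.min-1.g-1 in this assay, at which 1 of the 4 values shown sits.

On the core of compound 3, putting 2-fluorophenyl in place of neopentyl gives an at least 3.3-fold lower number from compound 3 to compound 4 (0.52 log units; beyond the scatter), whereas on the core of compound 2 the same change gives a 1.4-fold lower number from compound 2 to compound 1 (0.14 log units; within the scatter). The change therefore lowers the number beyond the scatter on one core but not on the other, yet this does not show that the core alters the size of the step, since the limit hides how far the number of compound 4 actually falls: the same change on two cores in this assay, a 1.4-fold lower number (0.14 log units; within the scatter) from compound 2 to compound 1 and an at least 3.3-fold lower number (0.52 log units; beyond the scatter) from compound 3 to compound 4; the limit leaves it open whether they differ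

The compounds shown leave open the true number for compound 4 and whether the step would hold on a third core, as this pair of groups is seen on only two cores. They also leave open how the clearance would read with another group at the same place, such as an unsubstituted phenyl, a cyclohexyl or a chain bearing an amine, on either core.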